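Swapping a Dimethylphenyl Sulfide for a Trifluoromethylpyridinyl Sulfide

The source may hold more compounds than are shown below. What is called first, only, known or untested is meant among the compounds shown, and "the series" means these compounds.

Compound 3 `Cc1cc(C)cc(SCc2ccc(/C=C/C(=O)Nc3ccccc3N)cc2)c1` stands lowest of the three measured compounds in a functional assay on A-375 cells (Homo sapiens) for inhibition, read by CCK-8 assay, with a stated time of 72 h, tested at 2 uM (on this read-out higher numbers stand for more inhibition of growth at the one concentration tested and lower numbers for less inhibition of growth), where compound 3 gives 8.78%. Its nearest neighbour is compound 2 `Nc1ccccc1NC(=O)/C=C/c1ccc(CSc2ccc(F)cc2)cc1`, which in this assay gives 28.8%, and the furthest is compound 1 `Nc1ccccc1NC(=O)c1ccc(CSc2nccc(C(F)(F)F)n2)cc1`, which in this assay gives 54.4%. Compound 4 `Nc1ccccc1NC(=O)/C=C/c1ccc(CSc2ccc(C(F)(F)F)cn2)cc1` has not yet been measured; it differs from compound 3 in one place: 5-(trifluoromethyl)pyridin-2-yl in place of 3,5-dimethylphenyl on a sulfur.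

Among the measured compounds shown here, the only measured step at this position is a number 20 percentage points lower from compound 2 to compound 3 (beyond the scatter), in which the ring on the sulfur was exchanged and the number fell. Compound 4 now leaves the 3,5-dimethylphenyl behind for a ring with one hetero atom and a trifluoromethyl group. Compound 1 also carries a trifluoromethyl-bearing ring with hetero atoms on its sulfur, though on a different core, and its value in this assay is the highest of the three; no single-step comparison links it to compound 3 or compound 4, so it offers only a hint. The account therefore expects compound 4 to move upward, a number 26.2 percentage points higher from compound 3 to compound 4 (beyond the scatter), with considerable uncertainty. The estimate for compound 4 in this assay is 35%, within a range from 15% to 60%.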

Compound 4, percent growth inhibition at one concentration: 10.3%
Compound 4: middle estimate off by 24.7 percentage points, on the high side; the measured number lies below the stated range.
By their numbers in this assay, from the lowest: compounds 3 and 4 (each within the scatter of the next); then compound 2; then compound 1.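

In this assay, replacing 3,5-dimethylphenyl with 5-(trifluoromethyl)pyridin-2-yl on a sulfur gives a number 1.5 percentage points higher from compound 3 to compound 4 (within the scatter), so this assay does not separate these two rings, even though one is a carbon-only ring and the other carries a hetero atom and trifluoromethyl. Measured against the 4-fluorophenyl group, the same new ring gives a number 18.5 percentage points lower from compound 2 to compound 4 (beyond the scatter), which shows that a second, quite different ring on this sulfur also stays beneath compound 2, as the 3,5-dimethylphenyl group did in a number 20 percentage points lower from compound 2 to compound 3 (beyond the scatter). No evidence is available on why the numbers at this position fall as they do.

On these data alone, whether an unsubstituted phenyl ring, or a phenyl ring bearing an amine or a carboxylic acid, would stand with compound 2 or with compound 3 and compound 4 remains open. Also open, as far as these compounds go, is how much of the value of compound 1, 54.4%, belongs to its core and how much to the ring on its sulfur.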